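Amide Side Chain Variation and Antiproliferative Potency

The compounds below may be only part of what the source reports. "The series", "measured", "known", "first", "only" and "open" are said of these compounds alone.

The compounds measured so far, in a functional assay on BXPC-3 cells (Homo sapiens) for antiproliferative activity, read by MTT assay, with a stated time of 24 h; a higher number here means a weaker inhibitor, a lower number a stronger inhibitor:
Compound 1 `CCn1c(C(=O)NCCC(=O)OC)ccc1C(CC)(CC)c1ccc(OCS(=O)(=O)c2ccccc2)c(C)c1` gives > 50000 nM, which is a limit of the assay rather than a number.
Compound 2 `CCn1c(C(=O)N[C@@H](C)CO)ccc1C(CC)(CC)c1ccc(OCS(=O)(=O)c2ccccc2)c(C)c1` gives 15300 nM.
Compound 3 `CCn1c(C(=O)N[C@@H](CO)CCO)ccc1C(CC)(CC)c1ccc(OCS(=O)(=O)c2ccccc2)c(C)c1` gives > 50000 nM, again only a limit of the assay.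

Compound 3 therefore stands at the weak end of what the assay can read, and the shared core with a 3-hydroxy-1-(hydroxymethyl)propyl group on the amide-type nitrogen yields no measurable number. Its position relative to compound 2 is given by an at least 3.2-fold higher number from compound 2 to compound 3 (0.51 log units; beyond the scatter), while a step that the two limits leave unreadable from compound 1 to compound 3 cannot be sized because both ends sit at the limit of > 50000 nM in this assay, at which 2 of the 3 values shown sit.

Compound 4 `CCn1c(C(=O)N[C@H](CC(=O)O)C(=O)O)ccc1C(CC)(CC)c1ccc(OCS(=O)(=O)c2ccccc2)c(C)c1` carries the change (1,2-dicarboxyethyl in place of 3-hydroxy-1-(hydroxymethyl)propyl on an amide-type nitrogen). Within the data shown here, the only steps that bear on it are those around the amide substituent: the gain seen in an at least 3.2-fold lower number from compound 1 to compound 2 (0.51 log units; beyond the scatter) and its reversal in an at least 3.2-fold higher number from compound 2 to compound 3 (0.51 log units; beyond the scatter), both at least modest. Neither involves a dicarboxyethyl group, so they give no direction for compound 4 beyond showing that larger polar substituents on this nitrogen have not improved matters. Compound 4 is accordingly expected to remain near the limit, with a step that the limit leaves unreadable from compound 3 to compound 4 amounting to no readable step. The estimate for compound 4 is 60000 nM, within 15000 nM to 200000 nM.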

Compound 4, half-maximal inhibitory concentration: > 50000 nM
Compound 4: no number, only a limit; the forecaster's own chance of this, stated with the estimate: 70%; the middle value is on the limit's open side.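

Compound 4 shows that the 1,2-dicarboxyethyl group on the amide-type nitrogen, like the 3-hydroxy-1-(hydroxymethyl)propyl group before it, does not keep the readable activity of the 1-(hydroxymethyl)ethyl group in this assay: the result is an at least 3.2-fold higher number from compound 2 to compound 4 (0.51 log units; beyond the scatter). Among the four compounds shown, compound 2 therefore remains the only one that gives a number rather than a limit, and the exchange of the hydroxyl-bearing substituent for the dicarboxyethyl group does not bring the series back into the readable range. The steps from compound 1 to compound 4 and from compound 3 to compound 4 cannot be read, because both ends of each sit at a limit: the limit of > 50000 nM in this assay, at which 3 of the 4 values shown sit.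

The compounds shown leave open how compound 1, compound 3 and compound 4 stand relative to one another, since none of the three has a number in this assay. They also leave open how an amine, or a longer chain ending in a single hydroxyl, would read on this amide-type nitrogen, and so whether anything on this nitrogen can improve on compound 2.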